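Ring-nitrogen methyl step repeated in a chlorinated pair

The source may hold more compounds than are shown below. What is called first, only, known or untested is meant among the compounds shown, and "the series" means these compounds.

Compound 1 `O=C1NC(=O)C(c2ccccc2)CC1c1ccccc1` gives 70.2% in a functional assay on the whole organism (strain Swiss albino) for inhibition, with Mus musculus as the target, in the maximal electroshock model, with a stated time of 2 h, at a dose of 25 mg/kg by the intraperitoneal route; a lower number here means less inhibition, a higher number more inhibition at the dose given (going by the name of the read-out). Compound 2 `CN1C(=O)C(c2ccccc2)CC(c2ccccc2)C1=O` gives 69.1% in this assay; it differs from compound 1 by methyl in place of hydrogen on an amide-type nitrogen in a ring, and the step is a number 1.1 percentage points lower from compound 1 to compound 2 (within the scatter). Compound 3 `O=C1NC(=O)C(c2ccccc2Cl)CC1c1ccccc1Cl` gives 58.3% in this assay; the difference between the core of compound 1 and the core of compound 3 is not broken down here. Compound 4 `CN1C(=O)C(c2ccccc2Cl)CC(c2ccccc2Cl)C1=O` is not yet measured and differs from compound 3 by methyl in place of hydrogen on an amide-type nitrogen in a ring. This is the same kind of change as from compound 1 to compound 2, the place differing only in that the two ring atoms each bear a 2-chlorophenyl group rather than a phenyl group. Given the step of a number 1.1 percentage points lower from compound 1 to compound 2 (within the scatter), the expected step is a number 1.3 percentage points lower from compound 3 to compound 4 (within the scatter). Compound 4 is therefore estimated to give 57% in this assay, expected to fall between 47% and 67%.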

Compound 4, a percentage reported as inhibition, in the whole organism at one dose (the size of the read-out at that dose, not a potency): 61.7%
For compound 4 the middle estimate is 4.7 percentage points below the measured one, and the stated range covers the measured number.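

In this assay, methyl in place of hydrogen on an amide-type nitrogen in a ring gives a number 3.4 percentage points higher from compound 3 to compound 4 (within the scatter), so on both cores the change stays within the scatter. The two steps do not differ: the same change on two cores in this assay, a number 1.1 percentage points lower (within the scatter) from compound 1 to compound 2 and a number 3.4 percentage points higher (within the scatter) from compound 3 to compound 4, 4.5 percentage points apart, within the scatter of two such steps. For the compounds shown here, this shows that the change carried from one core to the other without a step beyond the scatter, but it covers only two cores at a single dose, gives no potency and cannot fix the direction of any small effect.

Open, on these data alone, is whether an ethyl group, a longer chain or a chain ending in an amine on that nitrogen would behave as methyl does. Also open, as far as these compounds go, is whether the result holds with fluoro or methoxy on the phenyl groups.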